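The compounds below may be only part of what the source reports. "The series", "measured", "known", "first", "only" and "open" are said of these compounds alone.

Measured so far in a functional assay on MKN-45 cells (Homo sapiens) for inhibition, read by CCK-8 assay, with a stated time of 24 h; on this read-out lower numbers stand for stronger inhibition and higher numbers for weaker inhibition:
- compound 1 `O=C1Nc2ccccc2/C1=C/c1ccc(-c2cn(-c3ccc(F)cc3)nn2)cc1`: 16700 nM
- compound 2 `N#Cc1cccc(-n2cc(-c3ccc(/C=C4\C(=O)Nc5ccccc54)cc3)nn2)c1`: > 20000 nM (a limit of the assay, not a number)
- compound 3 `O=C1Nc2ccccc2/C1=C/c1ccc(-c2cn(-c3ccc(Cl)c(C(F)(F)F)c3)nn2)cc1`: 8890 nM

Compound 1 stands close to compound 3, and the two lie within the usual scatter of each other, as a 1.9-fold lower number from compound 1 to compound 3 (0.27 log units; within the scatter) shows. The only other result, for compound 2, is a limit.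

Compound 4 `O=C1Nc2ccc(F)cc2/C1=C/c1ccc(-c2cn(-c3ccc(F)cc3)nn2)cc1` is compound 1 with one change on the shared core: fluoro in place of hydrogen on an aromatic carbon. This is fluoro in place of hydrogen on an aromatic carbon of a six-membered aromatic ring of carbon only, part of a fused or bridged system of two rings.

Going by the values given here, no measured step touches that place. All three swap the group on an aromatic nitrogen: an at least 1.1-fold higher number from compound 1 to compound 2 (0.07 log units; that floor lies within the scatter), a 1.9-fold lower number from compound 1 to compound 3 (0.27 log units; within the scatter) and an at least 2.2-fold lower number from compound 2 to compound 3 (0.35 log units; beyond the scatter). They offer only a loose guide, and only the last goes beyond the scatter.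

With compound 1 at 16700 nM as the anchor, no shift beyond the scatter is expected, and the expected change is a 1.2-fold lower number from compound 1 to compound 4 (0.08 log units; within the scatter). For compound 4 the expected value is 14000 nM, with an estimated range of 6000 nM to 20000 nM.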

Compound 4, half-maximal inhibitory concentration: > 20000 nM
Compound 4 gave a limit, no number; the forecaster's own chance of this, stated with the estimate: 25%; middle value at least 1.4-fold (0.15 log units) from the limit.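

Going by these compounds alone, this is the first change to the shared core rather than to the group on the aromatic nitrogen, and in this assay fluoro in place of hydrogen on this aromatic carbon shows no gain in inhibition. The step reads an at least 1.1-fold higher number from compound 1 to compound 4 (0.07 log units; that floor lies within the scatter). Because the result for compound 4 is a limit of the assay and not a number, the step gives only a floor, and the true distance between the two compounds cannot be told: the limit of > 20000 nM in this assay, at which 2 of the 4 values shown sit.

The compounds shown leave open whether a different group at this place on the core, such as a methoxy group or an amine, would give a measurable value. They also leave open what fluoro at this place would do with 4-chloro-3-(trifluoromethyl)phenyl, the group carried by compound 3, on the aromatic nitrogen.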